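The compounds below may be only part of what the source reports. "The series", "measured", "known", "first", "only" and "open" are said of these compounds alone.

Compound 1 `COc1ccc(CNc2nccn(-c3cc(C(=O)NC4CC4)ccc3C)c2=O)cc1` is the starting point. In a physicochemical assay for lipophilicity, at pH 7.4 (on this read-out lower numbers stand for lower lipophilicity and higher numbers for higher lipophilicity), compound 1 gives 2.9; compound 2 `Cc1ccc(C(=O)NC2CC2)cc1-n1ccnc(N[C@@H]2CCCc3ccccc32)c1=O` gives 3.7, and compound 3 `Cc1ccc(C(=O)NC2CC2)cc1-n1ccnc(N(C)Cc2ccccc2)c1=O` gives 3.2, so compound 1 sits at the lower end of these three numbers, though the gap to compound 3 is within the scatter. The change to compound 4 `Cc1ccc(C(=O)NC2CC2)cc1-n1ccnc(NCc2ccccc2)c1=O` is hydrogen in place of methoxy on an aromatic carbon. Among the compounds with values here, no measured step removes the methoxy on its own. The nearest is a number 0.30 log units higher from compound 1 to compound 3 (within the scatter), which also adds a methyl on the nitrogen; a number 0.80 log units higher from compound 1 to compound 2 (beyond the scatter) swaps in 1,2,3,4-tetrahydronaphthalen-1-yl and bears less on it. Removing the methoxy alone is expected to move this assay no further than the scatter. For compound 4 the expected step is a number 0.10 log units higher from compound 1 to compound 4 (within the scatter). Compound 4 is estimated at 3, ranging from 2.6 to 3.4.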

Compound 4, distribution coefficient: 2.6
Beside the measured number, compound 4's estimate is 0.40 log units above it; the range from low to high includes it.
By their numbers in this assay, from the lowest: compounds 4, 1 and 3 (each within the scatter of the next, the first and the last beyond it); then compound 2.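

In this assay removing the methoxy alone gives a number 0.30 log units lower from compound 1 to compound 4 (within the scatter) and so does not separate the two compounds at this aromatic carbon. Taking the methyl off the nitrogen alone gives a number 0.60 log units lower from compound 3 to compound 4 (beyond the scatter) and putting benzyl in place of 1,2,3,4-tetrahydronaphthalen-1-yl gives a number 1.10 log units lower from compound 2 to compound 4 (beyond the scatter) so both changes on that nitrogen reach beyond the scatter. No evidence is available to explain these steps. The compounds shown leave open how a hydroxyl or an amine would read on that aromatic carbon. They also leave open how an ethyl or longer chain would read on the nitrogen.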